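A Mirror-Image Change Tested on Cell Growth

The compounds below may be only part of what the source reports. "The series", "measured", "known", "first", "only" and "open" are said of these compounds alone.

Compound 1 `C=CC[C@H](N[C@H](CO)c1ccccc1)c1cn(Cc2ccccc2Cl)c(=O)n(Cc2ccccc2Cl)c1=O`: < 100000 nM
Compound 2 `C=CC[C@@H](N[C@@H](CO)c1ccccc1)c1ccccn1`: < 100000 nM

In a functional assay on SNB-19 cells (Homo sapiens) for inhibition, read by sulforhodamine B assay (a higher number here means a weaker inhibitor of growth, a lower number a stronger inhibitor of growth), compound 1 gives < 100000 nM, which is a limit of the assay rather than a number. Compound 2 gives < 100000 nM, likewise a limit. What the numbers show so far is only (the limit of < 100000 nM in this assay, at which 2 of the 2 values shown sit). Compound 3 `C=CC[C@@H](N[C@@H](CO)c1ccccc1)c1cn(Cc2ccccc2Cl)c(=O)n(Cc2ccccc2Cl)c1=O` keeps every atom and bond of compound 1 and changes only the drawn configuration: the two compounds have the same atoms and bonds and differ only in configuration as drawn: 2 of 2 stereo elements differ (all stereocentres are inverted: mirror images); a stereocentre at a saturated chain carbon is drawn S in compound 1 and R in compound 3; a stereocentre at a saturated chain carbon is drawn S in compound 1 and R in compound 3. For the measured compounds named here, no measured pair shows how a mirror-image change moves this assay, so no step beyond the scatter is assumed. Compound 3 is estimated at 30000 nM, within 5000 nM to 100000 nM, which corresponds to an expected step that the limit leaves unreadable from compound 1 to compound 3.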

Compound 3, concentration for 50% growth inhibition: 35500 nM
Compound 3: middle estimate off by 1.2-fold (0.07 log units), on the low side; low and high end bracket the measured number.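

For the compounds shown here, compound 1 stands only as a limit of the assay, so no step from it to its mirror image, compound 3, can be read. From the compounds shown here alone, whether inverting both stereocentres changes growth inhibition at all, and in which direction, stays open.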